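Removing the Acetyl Ester from the Shared Core

The source may report more compounds than this note shows. Statements on the series, on what has been measured and on what is new or still open speak of the compounds shown alone.

Compound 1 `COc1ccc(/C=C/C(=O)OC[C@@H](OCc2ccccc2)[C@H]2OC(=O)C=C[C@H]2OCc2ccccc2)cc1` and compound 2 `CC(=O)OC[C@@H](OCc1ccccc1)[C@H]1OC(=O)C=C[C@H]1OCc1ccccc1` share the same core and differ only in the group attached to one ester carbonyl. In a functional assay on A549 cells (Homo sapiens) for antiproliferative activity, read by MTT assay, with a stated time of 6 days (a lower number here means a stronger inhibitor, a higher number a weaker inhibitor), compound 1 gives 4250 nM, while compound 2 gives 15000 nM. Among the compounds with values here, the step of a 3.5-fold higher number from compound 1 to compound 2 (0.55 log units; beyond the scatter) separates them, so compound 2 stands at the higher, weaker end of the two numbers measured so far. Compound 3 `O=C1C=C[C@@H](OCc2ccccc2)[C@@H]([C@@H](CO)OCc2ccccc2)O1` carries the change (hydrogen in place of acetyl on an oxygen on a saturated carbon), which removes the ester altogether and leaves a free hydroxyl. Within the data shown here, only one measured step bears on this: a 3.5-fold higher number from compound 1 to compound 2 (0.55 log units; beyond the scatter), where shrinking the ester group went with a weaker result. Taking the ester away entirely is expected to continue in that direction, if at all, only modestly: a 1.5-fold higher number from compound 2 to compound 3 (0.17 log units; within the scatter). Compound 3 is therefore expected to give about 22000 nM in this assay, within a range of 8000 nM to 60000 nM.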

Compound 3, half-maximal inhibitory concentration: 12900 nM
Compound 3: middle estimate off by 1.7-fold (0.23 log units), on the high side; the measured number falls inside the stated range.
By their numbers in this assay, from the lowest: compound 1; then compounds 3 and 2 (each within the scatter of the next).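

In this assay, going from acetoxy to hydroxy at this position gives a 1.2-fold lower number from compound 2 to compound 3 (0.07 log units; within the scatter), so the acetyl group and the bare hydrogen on this oxygen cannot be told apart, and the earlier trend of a smaller ester going with a higher number does not carry on past acetyl. The only clear difference at this oxygen is the one carried by the (2-(4-methoxyphenyl)ethenyl)carbonyl group, seen as a 3.0-fold higher number from compound 1 to compound 3 (0.48 log units; beyond the scatter), a step that sets compound 1 apart from both compound 2 and compound 3. Nothing available here explains why this group stands apart.

Still open, as far as these compounds go, is which part of that group matters: the methoxy group, the ethenyl link or the aromatic ring. A plain benzoyl ester, or an amine in place of the hydroxyl, could begin to separate these possibilities.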